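The source may hold more compounds than are shown below. What is called first, only, known or untested is meant among the compounds shown, and "the series" means these compounds.

Three compounds of the series carry numbers in a functional assay on DU-145 cells (Homo sapiens) for cytotoxicity, read by MTT assay, with a stated time of 48 h; on this read-out higher numbers stand for weaker inhibition and lower numbers for stronger inhibition. Compound 1 `Oc1ccc(-c2nc(-c3c[nH]c4ccccc34)co2)cc1` gives 247000 nM. Compound 2 `c1ccc2c(-c3coc(-c4ccncc4)n3)c[nH]c2c1` gives 178000 nM. Compound 3 `COc1cc(-c2nc(-c3c[nH]c4ccccc34)co2)ccc1O` gives 175000 nM. Compound 2 stands second highest of the three; compound 3 is nearest and compound 1 furthest, both within the scatter. Compound 4 `c1ccc2c(-c3coc(C4CCNCC4)n3)c[nH]c2c1` is not yet measured; it differs from compound 2 by piperidin-4-yl in place of pyridin-4-yl on an aromatic carbon. Going by the values given here, one measured step touches the same position, a 1.4-fold lower number from compound 1 to compound 2 (0.14 log units; within the scatter); the other, a 1.4-fold lower number from compound 1 to compound 3 (0.15 log units; within the scatter), lies elsewhere on the shared core. Both are within the scatter, so no step beyond it is expected in this assay. Compound 4 is therefore estimated at 200000 nM with a range of 70000 nM to 600000 nM, an expected step of a 1.1-fold higher number from compound 2 to compound 4 (0.05 log units; within the scatter).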

Compound 4, half-maximal inhibitory concentration: 381000 nM
Beside the measured number, compound 4's estimate is 1.9-fold (0.28 log units) below it; measured number inside the range.
By their numbers in this assay, from the lowest: compounds 3, 2, 1 and 4 (each within the scatter of the next, the first and the last beyond it).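

In this assay, going by these compounds alone, this position gives the first step beyond the scatter: the non-aromatic piperidin-4-yl in place of the aromatic pyridin-4-yl, with one hydrogen-bond donor more, gives a 2.1-fold higher number from compound 2 to compound 4 (0.33 log units; beyond the scatter) as a modest change. Against 4-hydroxyphenyl at the same place, piperidin-4-yl gives a 1.5-fold higher number from compound 1 to compound 4 (0.19 log units; within the scatter) and stays within the scatter. Nothing at hand explains the step.

Open, as far as these compounds go, is whether an open-chain amine such as aminomethyl or a carboxylic acid at this place would move the number further. Also open, from the compounds shown here alone, is whether N-methylpiperidin-4-yl would stay with piperidin-4-yl.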